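Methoxy to Ethoxy Step in the Shared-Core Ketone Series

The compounds below may be only part of what the source reports. "The series", "measured", "known", "first", "only" and "open" are said of these compounds alone.

Measured so far:
compound 1 `O=C(CSc1nc2ccccc2[nH]1)c1ccc(F)cc1` — "not active" (no number reported)
compound 2 `O=C(CSc1nc2ccccc2[nH]1)c1ccc(Br)cc1` — "not active" (no number reported)
compound 3 `COc1ccc(C(=O)CSc2nc3ccccc3[nH]2)cc1` — 52.6%

Within the data shown here, in a functional assay on HT-29 cells (Homo sapiens) for inhibition, read by flow cytometry, tested at 10 uM (on this read-out lower numbers stand for less inhibition and higher numbers for more inhibition at the one concentration tested (going by the name of the read-out)), compound 3 holds the only numerical result in the set; compound 1 and compound 2 are recorded without a number, so no step between two measured values can be drawn. Compound 4 `CCOc1ccc(C(=O)CSc2nc3ccccc3[nH]2)cc1` is the next member and differs from compound 3 by methyl in place of hydrogen on a saturated chain carbon bound to an oxygen on an aromatic ring. Among the measured compounds shown here, with no comparable step in the set, the change is expected to stay within the usual scatter of this assay, in neither direction beyond it. For compound 4 the expected step is a number 4.6 percentage points lower from compound 3 to compound 4 (within the scatter). Compound 4 is therefore estimated at 48%, with a range from 22% to 72%.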

Compound 4, a percentage reported as inhibition, at one concentration (the size of the read-out at that concentration, not a potency): 55.2%
The estimate for compound 4 lay 7.2 percentage points below the measured number; the measured number falls inside the stated range.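

In this assay, among these compounds, methoxy to ethoxy gives a number 2.6 percentage points higher from compound 3 to compound 4 (within the scatter), the first step that can be read, so this position accepts methyl in place of hydrogen on a saturated chain carbon bound to an oxygen on an aromatic ring without a change beyond the scatter. Steps involving compound 1 and compound 2 cannot be read, since neither carries a number. No evidence on the origin of this result is available.

Open, as far as these compounds go, is whether a longer chain such as butoxy keeps the read-out at this level. Also open, from the compounds shown here alone, is what an amine or a carboxylic acid at this place would do.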